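The source may report more compounds than this note shows. Statements on the series, on what has been measured and on what is new or still open speak of the compounds shown alone.

Measured compounds:
Compound 1, `COc1cc(-c2cc(/C=C/C(=O)c3ccc(Cl)c(Cl)c3)[nH]n2)cc(OC)c1OC`, gives 51%.
Compound 2, `COc1ccc(-c2cc(/C=C/C(=O)c3ccc(N)cc3)[nH]n2)cc1OC`, gives 37%.

Both numbers come from a functional assay on NCI/ADR-RES cells (Homo sapiens) for cytotoxicity, read by sulforhodamine B assay, with a stated time of 48 h, tested at 10 uM; on this read-out higher numbers stand for a weaker effect at the one concentration tested and lower numbers for a stronger effect. Of the two, compound 1 carries the higher number, so at the single concentration tested its effect is the weaker one; compound 2 sits lower by a margin beyond the usual scatter. The two differ in more than one place, so the pair shows only its two values and nothing is said here about which change accounts for the gap.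

Compound 3, `COc1ccc(C(=O)/C=C/c2cc(-c3cc(OC)c(OC)c(OC)c3)n[nH]2)cc1OC`, has not been measured. Against compound 1 it differs in one place: 3,4-dimethoxyphenyl in place of 3,4-dichlorophenyl on a carbonyl carbon. For the measured compounds named here, no measured pair isolates this change, so the expectation for compound 3 rests on the position of compound 1 alone. The step from compound 1 is expected to be small, a number 1 percentage points higher from compound 1 to compound 3 (within the scatter), with no clear direction beyond the scatter. Compound 3 is therefore estimated at 52%, within a range from 30% to 78%.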

Compound 3, a percentage reported as activity, at one concentration (the size of the read-out at that concentration, not a potency): 10%
The estimate for compound 3 lay 42 percentage points above the measured number, outside the stated range (below it).
By their numbers in this assay, from the lowest: compound 3; then compound 2; then compound 1.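

The change from 3,4-dichlorophenyl to 3,4-dimethoxyphenyl on a carbonyl carbon gives, in this assay, a number 41 percentage points lower from compound 1 to compound 3 (beyond the scatter), so the effect at the one concentration tested is clearly stronger with the new group. Compound 1 alone could not show this: with the rest of its structure unchanged, the read-out proves highly sensitive to the group at this position, and a swap between two groups that each carry one six-membered aromatic ring of carbon only is enough to move it well beyond the scatter. No measurement here bears on what lies behind this step.

This single pair does not tell whether both methoxy groups are needed for the step, or whether a single methoxy, a hydroxyl or an amine on that ring would read closer to compound 1 or to compound 3. It also leaves open whether the same change would have a similar effect with a different group on the other side of the core, and, since each value comes from one concentration, how potent compound 3 is.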